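Dropping a Methyl from a Curcumin-Like Diketone

The source may report more compounds than this note shows. Statements on the series, on what has been measured and on what is new or still open speak of the compounds shown alone.

Compound 1, `COc1cc(/C=C/C(O)=C/C(=O)c2c(O)cccc2OC)ccc1O`: 1680 nM
Compound 2, `COc1ccc(/C=C/C=C/C(=O)c2ccccc2O)cc1`: 1810 nM
Compound 3, `Cc1ccc(/C=C/C(O)=C/C(=O)c2ccccc2O)cc1`: 3770 nM

Three analogues sharing an aryl enol-ketone core were tested in an in vitro assay on cells for inhibition of Amine oxidase [flavin-containing] B (Homo sapiens), read by Amplex Red, with a stated time of 15 min; a lower number here means a stronger inhibitor, a higher number a weaker inhibitor. Compound 3 gives the highest number of the three, so on these numbers it is the weakest inhibitor. Compound 2 sits closest to it, and compound 1 furthest, yet both differ from compound 3 by more than the usual scatter, so the order among them is real.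

The next compound, compound 4, `O=C(/C=C(O)/C=C/c1ccccc1)c1ccccc1O`, is reached from compound 3 by a single change: hydrogen in place of methyl on an aromatic carbon. Among the measured compounds shown here, no pair among the measured compounds isolates this change, so the two neighbours cannot be used to read off its size. What the set does show is that compounds 1 and 2, which carry other groups on the corresponding ring, both land at lower numbers than compound 3. Removing the methyl is expected to shift the number only modestly, if at all, with the direction uncertain; the step from compound 3 is estimated at a 1.3-fold lower number from compound 3 to compound 4 (0.10 log units; within the scatter). Compound 4 is therefore expected to come in at about 3000 nM, somewhere between 1500 nM and 6500 nM.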

Compound 4, half-maximal inhibitory concentration: 1160 nM
The estimate for compound 4 lay 2.6-fold (0.41 log units) above the measured number; the measured number lies below the stated range.
By their numbers in this assay, from the lowest: compounds 4, 1 and 2 (each within the scatter of the next); then compound 3.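

Among the compounds shown here, removing the methyl gives a 3.3-fold lower number from compound 3 to compound 4 (0.51 log units; beyond the scatter) in this assay, and this is the first pair in the set to isolate a single change at this position, on an aromatic carbon para to a large group. The step lies beyond the scatter, so the position is not indifferent to this change: with the rest of the molecule held constant, the 4-methylphenyl to phenyl difference, which removes one carbon and adds no hydrogen-bond donor or acceptor, is enough to produce a real drop in the number. The earlier compounds shown here could not show this direction or size, since none of them formed a one-place pair, and the finding rests on this one pair alone. Nothing available bears on why the methyl has this effect.

On these data alone, whether the same step would appear on the core of compound 1 remains open, as does the question of whether it would appear on any other core. Also open, as far as these compounds go, is how a fluorine atom, an amine, a carboxylic acid or a longer chain such as ethyl at this same place would compare with the hydrogen of compound 4.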